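Replacing the 4-cyanophenyl group of compound 2

A few compounds are considered here, and "the series" means these few. Any claim that something is new, unique, unknown or untested is made for them only; others in the source may bear on it.

In a functional assay on PC-3 cells (Homo sapiens) for cytotoxicity, read by MTT assay, with a stated time of 72 h (a higher number here means a weaker inhibitor, a lower number a stronger inhibitor), compound 1 (`COc1ccc(OC)c(/C=C/C(=O)Nc2cc3c(Nc4ccc(F)c(Cl)c4)ncnc3cc2OC)c1`) gives 28600 nM and compound 2 (`N#Cc1ccc(/C=C/C(=O)Nc2cc3c(Nc4ccc(F)c(Cl)c4)ncnc3cc2O[C@H]2CCOC2)cc1`) gives 36600 nM. These two numbers lie within the scatter of each other, so compound 2 cannot be ranked against compound 1. Compound 3 (`COc1ccc(OC)c(/C=C/C(=O)Nc2cc3c(Nc4ccc(F)c(Cl)c4)ncnc3cc2O[C@H]2CCOC2)c1`) differs from compound 2 in one place: 2,5-dimethoxyphenyl in place of 4-cyanophenyl on a double-bonded chain carbon bound to a double-bonded chain carbon. The 2,5-dimethoxyphenyl group enters on a double-bonded chain carbon bound to a double-bonded chain carbon. Among the measured compounds shown here, no pair of measured compounds isolates this change yet. For the measured compounds named here, the only indirect evidence is that compound 1, which also carries the 2,5-dimethoxyphenyl group, gives 28600 nM. In this assay, a 1.2-fold lower number from compound 2 to compound 3 (0.09 log units; within the scatter) is therefore expected to stay within the scatter, with no clear direction. For compound 3 the estimated value is 30000 nM, with an expected range of 13000 nM to 70000 nM.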

Compound 3, half-maximal inhibitory concentration: 8730 nM
The estimate for compound 3 lay 3.4-fold (0.54 log units) above the measured number; measured number outside the range, below it.
By their numbers in this assay, from the lowest: compound 3; then compounds 1 and 2 (each within the scatter of the next).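

In this assay, the change to 2,5-dimethoxyphenyl from 4-cyanophenyl on a double-bonded chain carbon bound to a double-bonded chain carbon now has a direct reading: a 4.2-fold lower number from compound 2 to compound 3 (0.62 log units; beyond the scatter) with the oxolan-3-yl group held constant. Among the compounds shown here, the ether position also responds, since oxolan-3-yl in place of methyl on an oxygen on an aromatic ring gives a 3.3-fold lower number from compound 1 to compound 3 (0.52 log units; beyond the scatter) with the 2,5-dimethoxyphenyl group held constant, so compound 3, the one compound carrying both groups, has the lowest number of the three. Nothing at hand gives a reason for either step.

For the compounds shown here, whether the two steps would hold independently of each other remains open, as each has been read against only one partner group. Also open, on these data alone, is whether a phenyl ring with a single methoxy group, or a morpholine-bearing chain on the ether oxygen, would give a similar step.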